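This account rests on a few compounds, and the source may have more. Where it says the series, first, only, none or still open, it means among the compounds named here.

Compound 1 `N#CC1=C(N)Oc2c(c3nc4ccccc4nc3c3ccccc23)C12C(=O)N(Cc1cnnn1-c1ccccc1Cl)c1ccccc12` gives in a functional assay on HCT-116 cells (Homo sapiens) for antiproliferative activity, read by MTT assay, with a stated time of 48 h (a lower number here means a stronger inhibitor, a higher number a weaker inhibitor), the limit > 50000 nM.
Compound 2 `COc1ccc(-n2nncc2CN2C(=O)C3(C(C#N)=C(N)Oc4c3c3nc5ccccc5nc3c3ccccc43)c3ccccc32)cc1` gives in this assay the limit > 50000 nM.

Both of these values are limits of the assay and not numbers: neither compound reached a measurable inhibition within the tested range. Compound 2 therefore stands only at a limit, and the same is true of compound 1, which is all that the limit of > 50000 nM in this assay, at which 2 of the 2 values shown sit, shows. Among the compounds with values here, the only measured step, a step that the two limits leave unreadable from compound 1 to compound 2, joins two limits and cannot be read in size or direction.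

Compound 3 `CC(=O)Nc1ccc(-n2nncc2CN2C(=O)C3(C(C#N)=C(N)Oc4c3c3nc5ccccc5nc3c3ccccc43)c3ccccc32)cc1` differs from compound 2 by acetamido in place of methoxy on an aromatic carbon. No readable measured step bears on this change, and the two measured compounds give no direction to lean on, so no step beyond the scatter can be foreseen in this assay. Compound 3 is accordingly expected to remain at the limit, with an estimate of 60000 nM, ranging from 20000 nM to 200000 nM. That estimate means an expected step that the limit leaves unreadable from compound 2 to compound 3.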

Compound 3, half-maximal inhibitory concentration: > 50000 nM
Compound 3 was reported as a limit; the forecaster's own chance of this, stated with the estimate: 80%; the middle value does not contradict the limit.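

Compound 3 also gives only a limit, not a number, so its steps from compound 2 and from compound 1 cannot be read. All three compounds sit at the same limit: the limit of > 50000 nM in this assay, at which 3 of the 3 values shown sit.

The compounds shown leave open whether 2-chlorophenyl, 4-methoxyphenyl and 4-acetamidophenyl differ at all in this assay.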